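A few compounds are considered here, and "the series" means these few. Any claim that something is new, unique, unknown or untested is made for them only; others in the source may bear on it.

Compound 1 `COc1cc(O)c(C(=O)c2cccc(F)c2)c(OC)c1` gives 38%.
Compound 2 `COc1cc(OC)c(C(=O)c2cccc(Cl)c2)c(O)c1CN1CCCCC1` gives 33%.
Compound 3 `COc1cc(O)c(C(=O)c2ccccc2Br)c(OC)c1` gives 7%.

These three were tested in a functional assay on THP-1 cells (Homo sapiens) for inhibition, read by ELISA, with stated times of 30 min and 24 h, tested at 1 uM; on this read-out lower numbers stand for a weaker effect and higher numbers for a stronger effect at the one concentration tested. Compound 3 holds the lowest of the three numbers; the nearest to it is compound 2, and compound 1 lies furthest away, both gaps beyond the scatter. Compound 4 `COc1cc(OC)c(C(=O)c2ccccc2Br)c(O)c1CN1CCCCC1` has not yet been measured. It differs from compound 3 in one place: (piperidin-1-yl)methyl in place of hydrogen on an aromatic carbon. Going by the values given here, no pair of measured compounds isolates this change, so its effect is not known. Compound 2, which carries the (piperidin-1-yl)methyl group, and compound 1, which does not, sit within the scatter of each other, so only a small step, if any, is expected in this assay. Compound 4 is expected at 14%, a step of a number 7 percentage points higher from compound 3 to compound 4 (within the scatter), with a range from 0% to 35%.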

Compound 4, a percentage reported as activity, at one concentration (the size of the read-out at that concentration, not a potency): 22%
The estimate for compound 4 lay 8 percentage points below the measured number; low and high end bracket the measured number.
By their numbers in this assay, from the lowest: compound 3; then compound 4; then compounds 2 and 1 (each within the scatter of the next).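

In this assay, going by these compounds alone, (piperidin-1-yl)methyl in place of hydrogen on the aromatic carbon ortho to a hydroxy group gives a number 15 percentage points higher from compound 3 to compound 4 (beyond the scatter), the first isolated reading of this change, and the step is modest but beyond the scatter. With that group present, 2-bromophenyl in place of 3-chlorophenyl gives a number 11 percentage points lower from compound 2 to compound 4 (beyond the scatter), so the group on the carbonyl still alters the read-out. No evidence is available that bears on the reason for either step.

On these data alone, it remains open whether a smaller amine, such as dimethylaminomethyl, or a morpholin-4-ylmethyl group would give a similar step. As far as these compounds go, it is also open whether the (piperidin-1-yl)methyl step holds with 3-chlorophenyl on the carbonyl.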